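From Naphthalen-1-yl to 3-Methoxyphenoxy: Expected Solubility

This account rests on a few compounds, and the source may have more. Where it says the series, first, only, none or still open, it means among the compounds named here.

Compound 3 `c1coc(CNCCCNc2ccnc3cc(-c4cccc5ccccc45)ccc23)c1` gives 32000 nM in a physicochemical assay for solubility, with a stated time of 18 h, at pH 7.4 (a lower number here means a less soluble compound, a higher number a more soluble compound), level with compound 1 `COc1ccc(-c2ccc3c(NCCCNCc4ccco4)ccnc3c2)cc1` at 32000 nM, and these two together stand highest of the three measured compounds. Compound 2 `COc1ccc(Oc2ccc3c(NCCCNCc4ccco4)ccnc3c2)cc1` stands lowest at 14500 nM, and a 2.2-fold higher number from compound 2 to compound 3 (0.34 log units; beyond the scatter) marks that gap. Compound 4 `COc1cccc(Oc2ccc3c(NCCCNCc4ccco4)ccnc3c2)c1` differs from compound 3 by 3-methoxyphenoxy in place of naphthalen-1-yl on an aromatic carbon. Among the compounds with values here, two measured steps bear on this change, a 2.2-fold lower number from compound 1 to compound 2 (0.34 log units; beyond the scatter) and a 2.2-fold higher number from compound 2 to compound 3 (0.34 log units; beyond the scatter): each shows that 4-methoxyphenoxy at this position gives a modestly lower number than either 4-methoxyphenyl or naphthalen-1-yl. Within the data shown here, no measured pair separates 3-methoxyphenoxy from 4-methoxyphenoxy, so that difference stays open. Compound 4 is therefore expected to show a modest drop, a 2.1-fold lower number from compound 3 to compound 4 (0.33 log units; beyond the scatter), with an estimate of 15000 nM and a range from 7000 nM to 32000 nM.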

Compound 4, solubility: 14500 nM
Compound 4: the middle estimate sits 1.0-fold (0.01 log units) above what was measured; the range from low to high includes it.
By their numbers in this assay, from the lowest: compounds 2 and 4 (each within the scatter of the next); then compounds 1 and 3 (each within the scatter of the next).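

With 3-methoxyphenyl in place of 4-methoxyphenyl on the oxygen, this assay gives no change at the digits printed from compound 2 to compound 4 (within the scatter) and so settles the earlier open question: these two phenoxy groups do not differ here. Compound 4 joins compound 2 at the lower level, with a 2.2-fold lower number from compound 3 to compound 4 (0.34 log units; beyond the scatter) and with a 2.2-fold lower number from compound 1 to compound 4 (0.34 log units; beyond the scatter) as well, so the drop seen with 4-methoxyphenoxy holds for both of these placements of the methoxy group.

The data give no evidence on why the phenoxy compounds read lower. Also open, going by these compounds, is how a phenoxy group carrying an amine or a carboxylic acid in place of methoxy would read in this assay.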